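Working notes on a pyrazole-tetrazole series, compound 3 to compound 4

This account rests on a few compounds, and the source may have more. Where it says the series, first, only, none or still open, it means among the compounds named here.

Measured so far:
compound 1, `O=C(Cn1nnc(-c2ccccc2)n1)Nc1cc(C2(C(F)(F)F)CC2)nn1C1CCCCC1`: "not active" (no number reported)
compound 2, `Cc1cc(NC(=O)Cn2nnc(-c3ccccc3)n2)n(-c2ccccc2)n1`: 3020 nM
compound 3, `Cc1cc(NC(=O)Cn2nnc(-c3ccc(Cl)c(Cl)c3)n2)n(C2CCCCC2)n1`: 1220 nM

The read-out throughout is an assay on HEK293 cells for activation of Kir3.1/Kir3.2 (Homo sapiens), read by thallium flux; a lower number here means that less compound is needed, a higher number that more compound is needed for the effect. Compound 1 is reported in this assay as "not active" (no number reported), so it carries no number and is set aside for comparisons. Of the two numbers that exist, compound 3 has the lowest, at 1220 nM in this assay, and compound 2, at 3020 nM, sits at a higher number; the gap between the two lies beyond the scatter. Within the data shown here, the two measured compounds differ in more than one place, so no single step between measured compounds is available, and nothing in the data isolates the effect of the aromatic group on the tetrazole.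

Compound 4, `Cc1cc(NC(=O)Cn2nnc(-c3cccc(C#N)c3)n2)n(C2CCCCC2)n1`, is not yet measured. It differs from compound 3 in one place: 3-cyanophenyl in place of 3,4-dichlorophenyl on an aromatic carbon

Among the measured compounds shown here, with no matching step on record, the direction of this change is not fixed by the data. Compound 4 is expected to give a number somewhat above that of compound 3, because compound 3 holds the lowest number in this assay at 1220 nM and a move away from it more often goes up than down. The expected step is a 2.5-fold higher number from compound 3 to compound 4 (0.39 log units; beyond the scatter), a modest rise. Compound 4 is therefore estimated at 3000 nM in this assay, within a range from 1200 nM to 8000 nM.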

Compound 4, half-maximal effective concentration: 183 nM
Beside the measured number, compound 4's estimate is 16-fold (1.21 log units) above it, and the stated range ends above it.
By their numbers in this assay, from the lowest: compound 4; then compound 3; then compound 2.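

Among these compounds, the pair gives the first single-place step in this assay, where 3-cyanophenyl in place of 3,4-dichlorophenyl on an aromatic carbon of the five-membered aromatic ring with 4 nitrogen gives a 6.7-fold lower number from compound 3 to compound 4 (0.82 log units; beyond the scatter), showing that the number responds to the aromatic group held at this position. The heavy-atom count does not separate the two groups, and each holds one six-membered aromatic ring of carbon only, so the counted difference lies in the two chlorine atoms leaving and a triple bond and a hydrogen-bond acceptor entering. No measurement on hand ties the lower number to any one of these features.

The change removes the chlorine atoms and adds the nitrile at once, so the compounds shown leave open which part of the swap carries the step. Also open, as far as these compounds go, are how a carboxylic acid, an amine or a methoxy group in place of the nitrile would read in this assay, and whether the step would hold with the phenyl group of compound 2 in place of the cyclohexyl group.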